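Methoxyphenyl regioisomers on a triazole: a cytotoxicity comparison

The source may hold more compounds than are shown below. What is called first, only, known or untested is meant among the compounds shown, and "the series" means these compounds.

Measured compounds:
- compound 1, `Cc1ccccc1NC(=O)Cn1cc(COc2ccc3c(c2)CCC3)nn1`: "not determined" (no result reported)
- compound 2, `COc1ccccc1-n1cc(COc2ccc3c(c2)CCC3)nn1`: 19.8%
- compound 3, `CCc1ccc(NC(=O)Cn2cc(COc3ccc4c(c3)CCC4)nn2)cc1`: "not determined" (no result reported)

Three compounds share the core of compound 2, and all were entered in an ADME assay on HEK293 cells (Homo sapiens) for inhibition, read by MTT assay, with a stated time of 48 h, tested at 25 uM; a higher number here means more inhibition at the concentration tested (going by the name of the read-out), a lower number less inhibition. Only compound 2 came out with a number: in this assay compound 2 gives 19.8%. For compound 1 the entry in this assay is "not determined" (no result reported), and for compound 3 the entry is "not determined" (no result reported), so compound 2 stands alone among the numbers shown and cannot be ranked against anything.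

The compound now at issue is compound 4, `COc1cccc(-n2cc(COc3ccc4c(c3)CCC4)nn2)c1`. It differs from compound 2 in one place: 3-methoxyphenyl in place of 2-methoxyphenyl on an aromatic nitrogen. The same atoms are present in both; they are joined differently.

Among the measured compounds shown here, no step between two measured compounds is available, so there is nothing to set the size of this change against. With one value in hand and no comparison to guide the direction, the expected step from compound 2 to compound 4 in this assay is a number 2.2 percentage points higher from compound 2 to compound 4 (within the scatter), which is within the usual scatter and not a change in either direction.

On that basis compound 4 is expected to give about 22% in this assay, with a likely range from 8% to 38%.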

Compound 4, a percentage reported as inhibition, at one concentration (the size of the read-out at that concentration, not a potency): 25.8%
Compound 4: the middle estimate sits 3.8 percentage points below what was measured; the measured number falls inside the stated range.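

Among the compounds shown here, with 3-methoxyphenyl in place of 2-methoxyphenyl on the aromatic nitrogen, this assay gives a number 6 percentage points higher from compound 2 to compound 4 (within the scatter) and so supplies the first step that can be read for this series. It shows that this exchange of one methoxyphenyl group for the other, with the same atoms joined differently, does not separate the two compounds at the single concentration tested. Nothing available offers an explanation for how the two compounds read in this assay.

The compounds shown leave open whether an amine or a carboxylic acid in place of the methoxy group on the same phenyl ring would give a result in this assay that stands apart from those of compound 2 and compound 4. As far as these compounds go, it also remains open whether compound 2 and compound 4 would still be indistinguishable at a concentration other than the one used here.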